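Cyclisation of the thiosemicarbazide arm in the benzimidazole series

This account rests on a few compounds, and the source may have more. Where it says the series, first, only, none or still open, it means among the compounds named here.

Measured so far:
compound 1 `Cn1c(Cn2c(-c3ccc(Cl)cc3)nc3ccccc32)n[nH]c1=S`: 81%
compound 2 `CNC(=S)NNC(=O)Cn1c(-c2ccc(OC)c(OC)c2)nc2cc(Cl)c(Cl)cc21`: 70%

In a functional assay on microsomes from liver (Rattus norvegicus) for inhibition, tested at 1000 uM (a higher number here means more inhibition at the concentration tested (going by the name of the read-out), a lower number less inhibition), compound 1 gives 81% and compound 2 gives 70%. Compound 2 stands lowest of the two, with compound 1 beyond the scatter above it. Compound 3 `CNc1nnc(Cn2c(-c3ccc(OC)c(OC)c3)nc3cc(Cl)c(Cl)cc32)s1` differs from compound 2 by a group of 7 heavy atoms (3 carbon, 3 nitrogen, 1 sulfur; one five-membered aromatic ring with 3 hetero atoms) in place of a group of 8 heavy atoms (3 carbon, 3 nitrogen, 1 oxygen, 1 sulfur; no ring), on a saturated chain carbon bound to an aromatic nitrogen. Within the data shown here, no measured pair shares this change, so its size is unknown. The shift is expected to be modest and upward, as a number 6 percentage points higher from compound 2 to compound 3 (within the scatter), partly because compound 1, which also carries a ring at this position, gives 81%. Compound 3 is therefore expected at 76%, within 58% to 90%.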

Compound 3, a percentage reported as inhibition, at one concentration (the size of the read-out at that concentration, not a potency): 66%
The estimate for compound 3 lay 10 percentage points above the measured number; low and high end bracket the measured number.
By their numbers in this assay, from the lowest: compounds 3 and 2 (each within the scatter of the next); then compound 1.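

In this assay, placing 5-(methylamino)-1,3,4-thiadiazol-2-yl on the saturated chain carbon bound to an aromatic nitrogen, in place of the open-chain group, gives a number 4 percentage points lower from compound 2 to compound 3 (within the scatter). The open chain and this ring therefore cannot be told apart at this position at the single concentration tested. Nothing measured here offers an explanation for this result.

From the compounds shown here alone, whether a 1,3,4-oxadiazole ring, with oxygen in place of the ring sulfur, or a carboxylic acid on the same chain carbon would read alike stays open. Compound 1 differs from compound 3 in more than one place and cannot settle this.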